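The source may report more compounds than this note shows. Statements on the series, on what has been measured and on what is new or still open speak of the compounds shown alone.

Measured compounds:
compound 1 `CCCc1nc(CC)c(C(=O)OCCC[S+]([O-])c2ccccc2)n1Cc1ccc(-c2ccccc2S(=O)(=O)NC(=O)OCCC(C)C)cc1F` gives 1 nM
compound 2 `CCCc1nc(CC)c(C(=O)OCc2ccccc2Sc2ccccc2)n1Cc1ccc(-c2ccccc2S(=O)(=O)NC(=O)OCCC(C)C)cc1F` gives 2 nM
compound 3 `CCCc1nc(CC)c(C(=O)OCc2ccccc2C(=O)c2ccccc2)n1Cc1ccc(-c2ccccc2S(=O)(=O)NC(=O)OC)cc1` gives 10 nM

In an assay on isolated protein for binding affinity to Type-2 angiotensin II receptor (Homo sapiens) (on this read-out lower numbers stand for stronger inhibition and higher numbers for weaker inhibition), compound 2 stands second highest of the three numbers. Its nearest neighbour is compound 1, whose number lies within the scatter of that of compound 2; compound 3 stands beyond the scatter, with a higher number than compound 2.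

Compound 4 `CCCc1nc(CC)c(C(=O)OCc2ccccc2NC(=O)c2ccccc2)n1Cc1ccc(-c2ccccc2S(=O)(=O)NC(=O)OCCC(C)C)cc1F` differs from compound 2 in one place: benzamido in place of phenylsulfanyl on an aromatic carbon. For the measured compounds named here, no step between two measured compounds covers this change, so nothing shows its size directly. The estimate for this step is a 1.5-fold higher number from compound 2 to compound 4 (0.18 log units; within the scatter), a change not expected to exceed the scatter.

Compound 4 is therefore expected to give about 3 nM, within a range from 1 nM to 10 nM.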

Compound 4, half-maximal inhibitory concentration: 1 nM
Compound 4: middle estimate off by 3.0-fold (0.48 log units), on the high side; the range from low to high includes it.
By their numbers in this assay, from the lowest: compounds 1, 4 and 2 (each within the scatter of the next); then compound 3.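

In this assay benzamido in place of phenylsulfanyl on an aromatic carbon, ortho to a large group, gives a 2.0-fold lower number from compound 2 to compound 4 (0.30 log units; within the scatter) and so stays within the scatter. This position therefore accepts either group, and the carbonyl and amide hydrogen that enter with benzamido bring no readable step in this pair. Nothing measured here explains why the two groups read alike.

Still open, as far as these compounds go, is how a smaller group on this aromatic carbon, such as an amine or a carboxylic acid, would read. A longer chain between the amide carbonyl and the phenyl ring is equally untested in the compounds shown.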